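A few compounds are considered here, and "the series" means these few. Any claim that something is new, unique, unknown or untested is made for them only; others in the source may bear on it.

Of the compounds shown here, three have been measured in an ADME assay on Vero cells (Chlorocebus sabaeus) for cytotoxicity, read by crystal violet staining; on this read-out higher numbers stand for lower toxicity in this test and lower numbers for higher toxicity in this test. Compound 1 `Clc1cccc(/N=N/N2CCCCC2)c1` gives > 100000 nM, which is a limit of the assay and not a number. Compound 2 `c1ccc(/N=N/N2CCCCC2)cc1` gives > 100000 nM, again only a limit. Compound 3 `Clc1ccc(/N=N/N2CCCC2)cc1` gives > 100000 nM, also a limit.

From compound 2 to compound 1 the change is chloro in place of hydrogen on an aromatic carbon. The step that the two limits leave unreadable from compound 2 to compound 1 cannot be read, because both values sit at the limit of > 100000 nM in this assay, at which 3 of the 3 values shown sit. The difference between the core of compound 2 and the core of compound 3 is not broken down here.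

Compound 4 `Clc1ccc(/N=N/N2CCCC2)cc1Cl` has not yet been measured. It differs from compound 3 by chloro in place of hydrogen on an aromatic carbon. Going by the values given here, this is the same kind of change as the one from compound 2 to compound 1, but the surroundings differ: in compound 4 the entering chloro sits ortho to a chloro group and meta to a group of 7 heavy atoms, whereas in compound 1 it sits meta to a group of 8 heavy atoms.

For compound 4 in this assay the step from compound 3 is expected to be about a number no higher from compound 3 to compound 4 (the limit leaves the size open), which rests on the fact that every measured value sits at the limit of > 100000 nM in this assay, at which 3 of the 3 values shown sit, and the earlier step is unreadable. Compound 4 is therefore estimated at 100000 nM, with a range from 30000 nM to 300000 nM.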

Compound 4, half-maximal cytotoxic concentration: 58000 nM
The estimate for compound 4 lay 1.7-fold (0.24 log units) above the measured number; low and high end bracket the measured number.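

In this assay, chloro in place of hydrogen on an aromatic carbon gives an at least 1.7-fold lower number from compound 3 to compound 4 (0.23 log units; that floor lies within the scatter), which on its own does not establish a difference between the two compounds, though a larger step is not excluded. The same change on the other core cannot be read, so no two sizes can be set side by side, and whether the change carries from one core to the other is neither confirmed nor ruled out. The true size of the step also stays open because the value for compound 3 is only a limit of the assay: the limit of > 100000 nM in this assay, at which 3 of the 4 values shown sit.

The compounds shown leave open how other groups on that aromatic carbon, such as a methyl group, a methoxy group or a carboxylic acid, would compare with chloro in this test. They also leave open how a second chloro would read on the core of compound 1, where the entering chloro would have a different group of heavy atoms in its surroundings.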